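A few compounds are considered here, and "the series" means these few. Any claim that something is new, unique, unknown or untested is made for them only; others in the source may bear on it.

Of the compounds shown here, two have numbers so far. Compound 1 `CO[C@@H]1OC[C@@H](OC(C)=O)[C@@H](OC(C)=O)[C@]1(F)n1ccc(=O)[nH]c1=O` gives 55000 nM in an ADME assay on L1210/0 cells (Mus musculus) for cytotoxicity, with a stated time of 48 h; on this read-out higher numbers stand for weaker inhibition and lower numbers for stronger inhibition. Going by the values given here, compound 2 `O=c1[nH]c(=O)n([C@H]2C[C@H](O)[C@@H](CO)O2)cc1[N+](=O)[O-]` gives 130 nM in this assay, the lower of the two numbers; the gap to compound 1 is well beyond the scatter of repeated runs, and no single-point step joins these two structures, so the pair is read only by its two values.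

The next step leaves compound 2 and changes one place of the core: 5-hydroxypent-1-yn-1-yl in place of nitro on an aromatic carbon. The result is compound 3 `O=c1[nH]c(=O)n([C@H]2C[C@H](O)[C@@H](CO)O2)cc1C#CCCCO`, not yet measured in this assay.

Among the compounds with values here, no measured step offers a precedent for this exchange, so the expectation rests on compound 2 alone. A move to a higher number is expected, well beyond the scatter, with considerable uncertainty about its size; the step from compound 2 to compound 3 is estimated at a 38-fold higher number from compound 2 to compound 3 (1.59 log units; beyond the scatter). In this assay compound 3 is therefore expected near 5000 nM, within a range of 500 nM to 50000 nM.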

Compound 3, half-maximal inhibitory concentration: > 200000 nM
Compound 3 was reported as a limit; the forecaster's own chance of this, stated with the estimate: 10%; middle value at least 40-fold (1.60 log units) away from the limit.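

The exchange of nitro for 5-hydroxypent-1-yn-1-yl on this aromatic carbon, two atoms from the ring nitrogen, gives an at least 1500-fold higher number from compound 2 to compound 3 (3.18 log units; beyond the scatter) in this assay. Going by these compounds alone, this is the first single-place step, and it shows that the read-out responds very strongly to the group at this position, with the low number of the pair, 130 nM for compound 2, going with nitro. The reading for compound 3 is a limit of the assay and not a number, so the step has a lower bound only: the limit of > 200000 nM in this assay, at which 1 of the 3 values shown sits.

The compounds shown do not separate the parts of the entering group, so it remains open whether the triple bond, the length of the chain or its terminal hydroxyl goes with the higher number. Also open, going by these compounds, is where other groups at this position would fall relative to compound 2, for instance a nitrile, an amine, a carboxylic acid, or a shorter chain such as ethynyl.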